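Coumarin-3-carboxamides: amide nitrogen substitution and MAO-B inhibition

The source may hold more compounds than are shown below. What is called first, only, known or untested is meant among the compounds shown, and "the series" means these compounds.

Measured so far:
compound 1 `O=C(NC1CCCCC1)c1cc2ccc(OCc3ccccc3)cc2oc1=O`: 64500 nM
compound 2 `O=C(NCc1ccccc1)c1cc2ccc(OCc3ccccc3)cc2oc1=O`: 990 nM

In an in vitro assay on BTI-TN-5B1-4 cells for inhibition of Amine oxidase [flavin-containing] B (Homo sapiens), read by fluorescence (a higher number here means a weaker inhibitor, a lower number a stronger inhibitor), compound 2 gives 990 nM, the lowest number of the two, with compound 1 at 64500 nM. For the measured compounds named here, the one step measured, a 65-fold lower number from compound 1 to compound 2 (1.81 log units; beyond the scatter), shows that the substituent on the amide nitrogen sets the number strongly. Compound 3 `CN(C(=O)c1cc2ccc(OCc3ccccc3)cc2oc1=O)c1ccccc1` carries methyl(phenyl)amino in place of benzylamino on a carbonyl carbon, so the amide hydrogen goes and the ring sits directly on nitrogen. Going by the values given here, no measured step covers such a change; the single step only shows large sensitivity at this position. A weaker number is expected, an 8.1-fold higher number from compound 2 to compound 3 (0.91 log units; beyond the scatter). For compound 3 the estimate is 8000 nM, range 1500 nM to 40000 nM.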

Compound 3, half-maximal inhibitory concentration: 2370 nM
For compound 3 the middle estimate is 3.4-fold (0.53 log units) above the measured one, within the range that was stated.
By their numbers in this assay, from the lowest: compound 2; then compound 3; then compound 1.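

Replacing benzylamino with methyl(phenyl)amino gives only a 2.4-fold higher number from compound 2 to compound 3 (0.38 log units; beyond the scatter) even though the amide hydrogen goes and the ring now sits directly on nitrogen. Compound 3 also keeps most of the gain over the cyclohexyl amide, with a 27-fold lower number from compound 1 to compound 3 (1.43 log units; beyond the scatter) as the step. No evidence at hand accounts for either step.

On these data alone, the step from compound 2 to compound 3 changes the amide hydrogen and the ring attachment together, so their separate contributions remain open. Phenylamino and methyl(benzyl)amino on the same carbonyl carbon would separate the two.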